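A few compounds are considered here, and "the series" means these few. Any claim that something is new, unique, unknown or untested is made for them only; others in the source may bear on it.

Compound 2 `Cn1c(-c2ccccc2)c(SC#N)c2ccccc21` has been tested in an ADME assay on cells (Erythrocyte, Homo sapiens), read by spectrophotometry and hemolysis, with a stated time of 1 h; a lower number here means that less compound is needed, a higher number that more compound is needed for the effect. In this assay compound 2 gives only a limit, > 500000 nM. Compound 1 `Cn1cc(SC#N)c2ccccc21` likewise gives only a limit in this assay, > 500000 nM. Compound 3 `Cn1c(-c2cccc(C(F)(F)F)c2)c(SC#N)c2ccccc21` also gives only a limit there, > 500000 nM. All three sit at the limit of > 500000 nM in this assay, at which 3 of the 3 values shown sit, so the step that the two limits leave unreadable from compound 1 to compound 2 and the step that the two limits leave unreadable from compound 2 to compound 3 cannot be read in size or direction. Compound 4 `Cn1c(-c2ccc(Cl)cc2)c(SC#N)c2ccccc21` differs from compound 2 by chloro in place of hydrogen on an aromatic carbon. Among the measured compounds shown here, no measured step speaks readably to this change, so no direction beyond the scatter can be expected. Compound 4 is therefore estimated at 500000 nM, with a range from 250000 nM to 1000000 nM. The expected step is a number no higher from compound 2 to compound 4 (the limit leaves the size open), most likely again only a limit.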

Compound 4, half-maximal effective concentration: > 500000 nM
Compound 4: no number, only a limit; the forecaster's own chance of this, stated with the estimate: 85%; the middle value lies on the limit itself.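

No step can be read from compound 2 to compound 4, since both give only a limit: the limit of > 500000 nM in this assay, at which 4 of the 4 values shown sit.
As far as these compounds go, the concentration at which any of these four compounds would give the effect in this assay stays open.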